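Notes on the step from compound 1 to compound 4

This account rests on a few compounds, and the source may have more. Where it says the series, first, only, none or still open, it means among the compounds named here.

Measured in a functional assay on MCF7 cells (Homo sapiens) for antiproliferative activity, read by MTT assay, with a stated time of 48 h; a lower number here means a stronger inhibitor, a higher number a weaker inhibitor:
compound 1 `CC(=O)N1N=C(c2ccc3ccccc3c2)OC1c1ccccc1Cl`: 2.36 ug/mL
compound 2 `CC(=O)N1N=C(c2ccc3ccccc3c2)OC1c1ccc(F)cc1`: 3.02 ug/mL
compound 3 `CC(=O)N1N=C(c2ccc3ccccc3c2)OC1c1ccccc1[N+](=O)[O-]`: 18.2 ug/mL

Compound 1 has the lowest of the three numbers, with a 1.3-fold higher number from compound 1 to compound 2 (0.11 log units; within the scatter) as the nearest gap and a 7.7-fold higher number from compound 1 to compound 3 (0.89 log units; beyond the scatter) as the furthest. The first of these does not separate the two compounds.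

Compound 4 `CC(=O)N1N=C(c2ccc3ccccc3c2)OC1c1ccccn1` has not yet been measured. It carries pyridin-2-yl in place of the 2-chlorophenyl of compound 1 on a saturated ring carbon pyridin-2-yl in place of 2-chlorophenyl on a saturated ring carbon and keeps the rest of the core of compound 1.

The measured changes at this carbon point in two directions. The 4-fluorophenyl group leaves the number within the scatter of compound 1, while a 6.0-fold higher number from compound 2 to compound 3 (0.78 log units; beyond the scatter) shows a larger move with the 2-nitrophenyl group. Within the data shown here, no measured compound has a hetero atom in this aromatic ring, so the three values bound the expectation only loosely. With compound 2 at 3.02 ug/mL and compound 3 at 18.2 ug/mL as the available outcomes, a modest move to a higher number is expected in this assay and not a lower one. The estimated step is a 2.5-fold higher number from compound 1 to compound 4 (0.41 log units; beyond the scatter) and it stays uncertain. Compound 4 is estimated at 6 ug/mL (expected range 2 ug/mL to 20 ug/mL).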

Compound 4, half-maximal inhibitory concentration: 6.02 ug/mL
Compound 4: middle estimate off by 1.0-fold (0.00 log units), on the low side; low and high end bracket the measured number.
By their numbers in this assay, from the lowest: compounds 1, 2 and 4 (each within the scatter of the next, the first and the last beyond it); then compound 3.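

In this assay, among these compounds, pyridin-2-yl is the only group at this saturated ring carbon with a hetero atom in its aromatic ring, and the change gives a 2.6-fold higher number from compound 1 to compound 4 (0.41 log units; beyond the scatter); the 4-fluorophenyl of compound 2 did not separate from compound 1 in this way. The ring nitrogen does not set compound 4 apart from every phenyl-bearing compound, since the series shows a 2.0-fold higher number from compound 2 to compound 4 (0.30 log units; within the scatter) and compound 4 therefore cannot be ordered against compound 2, while it remains clear of the 2-nitrophenyl compound with a 3.0-fold lower number from compound 3 to compound 4 (0.48 log units; beyond the scatter). No measured evidence bears on why these steps take the size they do.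

The compounds shown leave open whether the step from compound 1 belongs to the loss of the chloro group or to the gain of the ring nitrogen, a question that an unsubstituted phenyl group at this carbon would address. Also open, from the compounds shown here alone, is how far the result depends on where the nitrogen sits in the ring, as pyridin-3-yl and pyridin-4-yl would show, and whether an aminomethyl or carboxylic acid group on the ring would be tolerated.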